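A few compounds are considered here, and "the series" means these few. Any claim that something is new, unique, unknown or untested is made for them only; others in the source may bear on it.

Compound 1 `Nc1nc(O)c2c(n1)n(C1OC(CO)[C@@H](O)[C@H]1O)c(=O)n2Cc1ccc(Cl)cc1` carries a 4-chlorobenzyl group on its shared core. In a functional assay (B cells) with Mus musculus as the target (a higher number here means that more compound is needed for the effect, a lower number that less compound is needed), compound 1 gives 14 uM. Compound 3 `C=CCn1c(=S)n(COCCO)c2nc(N)nc(O)c21` gives 14 uM in this assay, the same number as compound 1 at the digits shown, and these two hold the highest values of the three. Compound 2 `C=CCn1c(=O)n(C2OC(CO[Si](C)(C)C(C)(C)C)[C@@H](O)[C@H]2O)c2nc(N)nc(O)c21` gives 1 uM in this assay, a lower number than compound 1 by more than the usual scatter. Compound 4 `CN(C)CCCn1c(=O)n(C2OC(CO)[C@@H](O)[C@H]2O)c2nc(N)nc(O)c21` has not been measured; its difference from compound 1 is 2-(dimethylamino)ethyl in place of 4-chlorophenyl on a saturated chain carbon bound to an aromatic nitrogen. Among the measured compounds shown here, no measured pair shows this change by itself, so the size of the step is unknown. The step of a 1.4-fold higher number from compound 1 to compound 4 (0.15 log units; within the scatter) is expected to stay within the scatter or lean toward a somewhat higher number. Compound 4 is estimated at 20 uM, within a range from 5 uM to 80 uM.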

Compound 4, concentration for half-maximal effect: 194 uM
Compound 4: the middle estimate sits 9.7-fold (0.99 log units) below what was measured; the measured number lies above the stated range.
By their numbers in this assay, from the lowest: compound 2; then compounds 1 and 3 (each within the scatter of the next); then compound 4.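

Replacing 4-chlorobenzyl with 3-(dimethylamino)propyl gives a 14-fold higher number from compound 1 to compound 4 (1.14 log units; beyond the scatter) in this assay and so shows that the group at this place on the shared core can move the number well beyond the scatter. Among the compounds shown here, the earlier compounds formed no pair differing in one place, so this is the first size seen for such a change. Nothing measured here accounts for that size.

The aromatic ring with its chlorine leaves as the amine enters, so the compounds shown do not separate the two. A plain benzyl group or an unbranched propyl chain without the amine would tell them apart.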